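Chloro to trifluoromethyl on a urea that shows no activity

The source may hold more compounds than are shown below. What is called first, only, known or untested is meant among the compounds shown, and "the series" means these compounds.

Compound 2 `O=C(Nc1cccc(-n2cc(-c3ccncc3)c(-c3ccc(Cl)c(O)c3)n2)c1)Nc1ccc(Cl)c(Cl)c1` is followed here through a single change. In a functional assay on NCI-H322M cells (Homo sapiens) for inhibition, read by sulforhodamine B assay, with a stated time of 48 h (on this read-out higher numbers stand for weaker inhibition of growth and lower numbers for stronger inhibition of growth), compound 2 reaches only the limit > 32500 nM, so no number for it is known. Compound 1 `COc1cc(-c2nn(-c3cccc(NC(=O)Nc4ccc(Cl)c(Cl)c4)c3)cc2-c2ccncc2)ccc1Cl` likewise stands at a limit in this assay, > 50000 nM. Compound 3 `COc1cc(-c2nn(-c3cccc(NC(=O)c4ccccc4)c3)cc2-c2ccncc2)ccc1Cl` also stands at a limit in this assay, > 100000 nM. The step that the two limits leave unreadable from compound 1 to compound 2 and the step that the two limits leave unreadable from compound 1 to compound 3 therefore cannot be read, and compound 2 cannot be placed relative to the other two beyond the fact that all three values are limits (the limit of > 100000 nM in this assay, at which 1 of the 3 values shown sits, (the limit of > 32500 nM in this assay, at which 1 of the 3 values shown sits), (the limit of > 50000 nM in this assay, at which 1 of the 3 values shown sits)).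

Compound 4 `O=C(Nc1cccc(-n2cc(-c3ccncc3)c(-c3ccc(Cl)c(O)c3)n2)c1)Nc1ccc(Cl)c(C(F)(F)F)c1` differs from compound 2 by trifluoromethyl in place of chloro on an aromatic carbon. Going by the values given here, no measured step touches this position, and the two steps that exist are themselves unreadable, so they give neither a size nor a direction. The step that the limit leaves unreadable from compound 2 to compound 4 is expected to carry no readable size in this assay. Compound 4 is estimated at 60000 nM, between 10000 nM and 300000 nM, and most likely again only a limit would be reported.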

Compound 4, concentration for total growth inhibition: 4480 nM
Estimate against measurement, compound 4: 13-fold (1.13 log units) above, outside the stated range (below it).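

In this assay, trifluoromethyl in place of chloro on an aromatic carbon gives an at least 7.2-fold lower number from compound 2 to compound 4 (0.86 log units; beyond the scatter), and lower numbers here stand for stronger inhibition of growth. Going by these compounds alone, this is the first readable step: it shows that the 3,4-dichlorophenyl end of the urea is a place where one substitution, with the rest of compound 2 unchanged, can bring the read-out from a limit to a measured number. Nothing shown here gives a measured reason why trifluoromethyl has this effect where chloro does not.

Going by these compounds, it remains open how a bromo, methyl or nitrile group at this carbon would compare with trifluoromethyl. On these data alone, it also remains open whether the same replacement would have a similar effect on compound 1, which carries the methyl on the oxygen.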